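This account rests on a few compounds, and the source may have more. Where it says the series, first, only, none or still open, it means among the compounds named here.

Measured so far in an ADME assay on BHK-21 cells (Mesocricetus auratus) for cytotoxicity, read by MTT assay, with a stated time of 96 h; on this read-out higher numbers stand for lower toxicity in this test and lower numbers for higher toxicity in this test:
Compound 1 `Cc1ccc(/N=N/N(C)c2ccccc2)cc1`: > 100000 nM (a limit)
Compound 2 `Cc1ccc(/N=N/c2ccc(NCCCN(C)C)cc2)cc1`: > 100000 nM (a limit)

Neither compound has yielded a number, and the record so far is the limit of > 100000 nM in this assay, at which 2 of the 2 values shown sit. Compound 2 therefore has no exact place on the scale. In this assay compound 2 gives > 100000 nM, which is a limit of the assay.

Compound 3 `CN(C)CCCNc1ccc(/N=N/c2ccccc2)cc1` differs from compound 2 in one place: hydrogen in place of methyl on an aromatic carbon. This is hydrogen in place of methyl on an aromatic carbon, which reads as 4-methylphenyl to phenyl. Among the compounds with values here, no measured pair shows this change, so the expectation in this assay is of no step beyond the usual scatter in either direction. The expected step, a number no higher from compound 2 to compound 3 (the limit leaves the size open), rests only on compound 2 and its limit of > 100000 nM. Compound 3 is estimated at 100000 nM, with an expected range from 40000 nM to 200000 nM.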

Compound 3, half-maximal cytotoxic concentration: 31000 nM
Estimate against measurement, compound 3: 3.2-fold (0.51 log units) above; measured number below the stated range.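

With compound 3, the series gains its first exact number in this assay, and the aromatic carbon para to a large group proves to be a place where a small change registers. Replacing 4-methylphenyl with phenyl gives an at least 3.2-fold lower number from compound 2 to compound 3 (0.50 log units; beyond the scatter), so removing this single methyl is enough to move the read-out toward higher toxicity in this test. The full size of the step cannot be read, because compound 2 is held only by a limit and the step is therefore a lower bound: the limit of > 100000 nM in this assay, at which 2 of the 3 values shown sit.

From the compounds shown here alone, whether a methoxy group or a chlorine atom at this place would also give a lower number remains open. The compounds shown also do not tell whether the same change would give a similar step with a shorter chain in place of the dimethylaminopropyl chain.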